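Amide variation on the shared core: toward compound 3

The source may report more compounds than this note shows. Statements on the series, on what has been measured and on what is new or still open speak of the compounds shown alone.

Measured so far:
compound 1 `O=C(C1CC1)N1CCc2nc(C#Cc3ccccc3)sc2C1`: 290 nM
compound 2 `CC1CCCC(C(=O)N2CCc3nc(C#Cc4ccccc4)sc3C2)C1`: > 10000 nM

In an assay on HEK293 cells for negative allosteric modulation of metabotropic glutamate receptor 5 (Homo sapiens), read by FLIPR, with a stated time of 1 h (a lower number here means a stronger inhibitor, a higher number a weaker inhibitor), compound 1 gives 290 nM. For compound 2 the result > 10000 nM is a limit of the assay, not a number. Compound 2 thus stands at the limit of > 10000 nM in this assay, at which 1 of the 2 values shown sits, the weaker end of what has been seen. Among the compounds with values here, the single measured step, an at least 34-fold higher number from compound 1 to compound 2 (1.53 log units; beyond the scatter), shows that the group on this carbonyl carbon can shift the number by a large amount.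

Compound 3 `N#Cc1cccc(C(=O)N2CCc3nc(C#Cc4ccccc4)sc3C2)c1` differs from compound 2 by 3-cyanophenyl in place of 3-methylcyclohexyl on a carbonyl carbon. Within the data shown here, no measured step covers an aromatic group at this position, so the measured step gives only the scale of what is possible here, not the direction. As compound 2 sits at the limit, any step beyond the scatter can only appear as a lower number. The expectation is that compound 3 returns toward the range of compound 1, an estimated step of an at least 16-fold lower number from compound 2 to compound 3 (1.22 log units; beyond the scatter). Compound 3 is therefore estimated at 600 nM, with a range from 100 nM to 5000 nM.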

Compound 3, half-maximal inhibitory concentration: > 10000 nM
Compound 3 ended at the assay's limit; the forecaster's own chance of this, stated with the estimate: 15%; at least 16-fold (1.22 log units) between middle value and limit.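

In this assay, 3-cyanophenyl in place of cyclopropyl on the carbonyl carbon gives an at least 34-fold higher number from compound 1 to compound 3 (1.53 log units; beyond the scatter), so an aromatic ring at this position does not bring the number back toward the readable range. With a six-membered ring of either kind, non-aromatic or aromatic, the result is now a limit of the assay, and the cyclopropyl amide remains the only compound shown with a readable value. The step between compound 2 and compound 3 cannot be read, so these two groups cannot be ranked, and the position as shown mostly sits at the limit: the limit of > 10000 nM in this assay, at which 2 of the 3 values shown sit.

Going by these compounds, whether a cyclobutyl or an isopropyl group on this carbonyl carbon keeps a readable value stays open. So does whether an unsubstituted phenyl or a pyridyl ring behaves as 3-cyanophenyl does here.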